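The source may report more compounds than this note shows. Statements on the series, on what has been measured and on what is new or still open speak of the compounds shown alone.

Of the compounds shown here, three sharing one core have been tested in an ADME assay on L02 cells (Homo sapiens) for cytotoxicity, read by MTT assay, with a stated time of 48 h; on this read-out lower numbers stand for stronger inhibition and higher numbers for weaker inhibition. Compound 1 `CCn1c(C(=O)NCC(OC)OC)ccc1C(CC)(CC)c1ccc(OCC(O)C(C)(C)C)c(C)c1` gives 22200 nM, compound 2 `CCn1c(C(=O)N(C)CCC#N)ccc1C(CC)(CC)c1ccc(OCC(O)C(C)(C)C)c(C)c1` gives 14900 nM, and compound 3 `C=CCN(C)C(=O)c1ccc(C(CC)(CC)c2ccc(OCC(O)C(C)(C)C)c(C)c2)n1CC` gives 6300 nM, the lowest number of the three. Compound 4 `CC[C@@H](C)[C@H](NC(=O)c1ccc(C(CC)(CC)c2ccc(OCC(O)C(C)(C)C)c(C)c2)n1CC)C(=O)O` differs from compound 3 on a carbonyl carbon: (1-carboxy-2-methylbutyl)amino in place of allyl(methyl)amino on a carbonyl carbon. In short, (1-carboxy-2-methylbutyl)amino takes the place of allyl(methyl)amino.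

Two measured steps at that same carbonyl carbon bear on this change: a 3.5-fold lower number from compound 1 to compound 3 (0.55 log units; beyond the scatter) and a 2.4-fold lower number from compound 2 to compound 3 (0.37 log units; beyond the scatter). Read in reverse, both show that replacing allyl(methyl)amino went with a modestly higher number. Compound 1 is the closest guide, as it keeps the amide hydrogen that compound 4 also has, and compound 1 gives 22200 nM. For the measured compounds named here, none of the measured compounds carries a carboxy group, so the range must stay wide.

A modest step towards a higher number is therefore expected in this assay, estimated as a 3.2-fold higher number from compound 3 to compound 4 (0.50 log units; beyond the scatter). Compound 4 is expected at about 20000 nM, within an estimated range of 7000 nM to 60000 nM.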

Compound 4, half-maximal inhibitory concentration: 1400 nM
For compound 4 the middle estimate is 14-fold (1.15 log units) above the measured one, and the stated range ends above it.
By their numbers in this assay, from the lowest: compound 4; then compound 3; then compounds 2 and 1 (each within the scatter of the next).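

For the compounds shown here, at this carbonyl carbon in this assay, (1-carboxy-2-methylbutyl)amino goes with a lower number than allyl(methyl)amino, with a 4.5-fold lower number from compound 3 to compound 4 (0.65 log units; beyond the scatter) running against the direction of the earlier steps. Keeping the amide hydrogen therefore does not tie this position to a high number: with that hydrogen present in both compounds, changing only the group on the nitrogen gives a 16-fold lower number from compound 1 to compound 4 (1.20 log units; beyond the scatter) as the largest step in the set. The position also answers strongly to the group placed there, as an 11-fold lower number from compound 2 to compound 4 (1.03 log units; beyond the scatter) is likewise a large step.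

No measurement shown here offers an explanation for this change. From the compounds shown here alone, whether the carboxylic acid, the branched chain or the defined stereocentres go with the lower number remains open, and a methyl ester or a carboxymethyl group on the amide nitrogen would help to separate them.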